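Fluorine position on the saturated ring carbon

This account rests on a few compounds, and the source may have more. Where it says the series, first, only, none or still open, it means among the compounds named here.

In a functional assay on WM 266-4 cells (Homo sapiens) for inhibition, read by MTT assay, with a stated time of 24 h (on this read-out higher numbers stand for weaker inhibition of growth and lower numbers for stronger inhibition of growth), the three measured compounds give the following:

Compound 1 `O=C(c1ccc2c(c1)OCCO2)N1N=C(c2ccc(Br)cc2)CC1c1cccc(F)c1`: 810 nM
Compound 2 `COc1ccc(C2=NN(C(=O)c3ccc4c(c3)OCCO4)C(c3ccccc3F)C2)cc1`: 3470 nM
Compound 3 `O=C(c1ccc2c(c1)OCCO2)N1N=C(c2ccc(Br)cc2)CC1c1ccccc1F`: 580 nM

Compound 4 `COc1ccc(C2=NN(C(=O)c3ccc4c(c3)OCCO4)C(c3cccc(F)c3)C2)cc1` has not been measured in this assay. It differs from compound 2 by 3-fluorophenyl in place of 2-fluorophenyl on a saturated ring carbon. The same kind of change has been measured once, from compound 3 to compound 1, as 3-fluorophenyl in place of 2-fluorophenyl on a saturated ring carbon; there it gave a 1.4-fold higher number from compound 3 to compound 1 (0.15 log units; within the scatter). The surroundings of the place are not identical: in compound 3 the ring atom two ring bonds away bears a 4-bromophenyl group (7 heavy atoms), in compound 2 it bears a 4-methoxyphenyl group (8 heavy atoms). The two cores themselves differ by methoxy in place of bromo on an aromatic carbon, and that difference gave a 6.0-fold lower number from compound 2 to compound 3 (0.78 log units; beyond the scatter), so compound 2 stands at the weak end of the set.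

Because the measured step of a 1.4-fold higher number from compound 3 to compound 1 (0.15 log units; within the scatter) lay within the scatter, compound 4 is expected to sit close to compound 2, the expected step being a 1.3-fold higher number from compound 2 to compound 4 (0.11 log units; within the scatter). Compound 4 is therefore estimated at 4500 nM in this assay, with a range from 2000 nM to 10000 nM.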

Compound 4, concentration for 50% growth inhibition: 930 nM
Estimate against measurement, compound 4: 4.8-fold (0.68 log units) above; the whole stated range lies above it.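

In this assay, the change from 2-fluorophenyl to 3-fluorophenyl gave a 3.7-fold lower number from compound 2 to compound 4 (0.57 log units; beyond the scatter), so it did not carry over from the core of compound 3 to the core of compound 2 with the same size: the same change on two cores in this assay, a 1.4-fold higher number (0.15 log units; within the scatter) from compound 3 to compound 1 and a 3.7-fold lower number (0.57 log units; beyond the scatter) from compound 2 to compound 4, 5.2-fold (0.72 log units) apart, beyond the scatter of two such steps With 3-fluorophenyl in place, the change from bromo to methoxy gave a 1.1-fold higher number from compound 1 to compound 4 (0.06 log units; within the scatter), so the effect of that second change likewise depended on the fluorine position: the same change on two cores in this assay, a 6.0-fold lower number (0.78 log units; beyond the scatter) from compound 2 to compound 3 and a 1.1-fold lower number (0.06 log units; within the scatter) from compound 4 to compound 1, 5.2-fold (0.72 log units) apart, beyond the scatter of two such steps These four compounds show that the two changes do not simply add, but each comparison rests on a single pair of steps, and they do not show why the steps differ or whether this holds for other groups.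

From the compounds shown here alone, it remains open whether an unsubstituted phenyl group on the saturated ring carbon would show the same dependence on the core. Going by these compounds, it also remains open whether chloro or ethoxy in place of bromo or methoxy would do so.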